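Pyridin-3-yl on the ring amine: what to expect

A few compounds are considered here, and "the series" means these few. Any claim that something is new, unique, unknown or untested is made for them only; others in the source may bear on it.

Measured so far:
compound 1, `Nc1scc(CN2CCN(c3ccc(Cl)cc3F)CC2)c1C(=O)c1ccc(Cl)cc1`, -9.2%
compound 2, `COc1ccc(N2CCN(Cc3csc(N)c3C(=O)c3ccc(Cl)cc3)CC2)cc1`, -1.2%
compound 3, `Nc1scc(CN2CCN(c3ccccc3C(F)(F)F)CC2)c1C(=O)c1ccc(Cl)cc1`, 0%

Three compounds share one core and differ only in the group on an amine nitrogen in a ring. In a functional assay on CHO cells with adenosine receptor A1 (Homo sapiens) as the target, read by cAMP accumulation and immunoassay, with a stated time of 6 min, tested at 0.01 uM (on this read-out lower numbers stand for a stronger effect and higher numbers for a weaker effect at the one concentration tested), all three sit close to zero. Among the compounds with values here, compound 3 gives the highest of the three numbers, yet the gaps are small: a number 1.2 percentage points higher from compound 2 to compound 3 (within the scatter) and a number 9.2 percentage points higher from compound 1 to compound 3 (within the scatter), each within the scatter, so no compound can be called stronger or weaker than another here.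

Compound 4 is `Nc1scc(CN2CCN(c3cccnc3)CC2)c1C(=O)c1ccc(Cl)cc1`. The change from compound 3 is pyridin-3-yl in place of 2-(trifluoromethyl)phenyl on an amine nitrogen in a ring. Every measured step also swaps the group at this same place, and none of them moved the read-out beyond the scatter: a number 8 percentage points higher from compound 1 to compound 2 (within the scatter), a number 9.2 percentage points higher from compound 1 to compound 3 (within the scatter), a number 1.2 percentage points higher from compound 2 to compound 3 (within the scatter). A fourth swap at the same place is therefore expected to behave alike, and the step of a number 2 percentage points lower from compound 3 to compound 4 (within the scatter) is estimated to stay within the scatter. Compound 4 is expected to give about -2%, with a range from -12% to 8%.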

Compound 4, a percentage reported as activity, at one concentration (the size of the read-out at that concentration, not a potency): 3.2%
Estimate against measurement, compound 4: 5.2 percentage points below, within the range that was stated.
By their numbers in this assay, from the lowest: compounds 1, 2, 3 and 4 (each within the scatter of the next, the first and the last beyond it).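

Within the data shown here, putting pyridin-3-yl on the ring amine brings a hetero atom and a hydrogen-bond acceptor into this aromatic ring for the first time, yet this assay separates compound 4 from neither neighbour: the read-out shows a number 3.2 percentage points higher from compound 3 to compound 4 (within the scatter) and a number 4.4 percentage points higher from compound 2 to compound 4 (within the scatter). Among these compounds, the one step that clears the scatter is a number 12.4 percentage points higher from compound 1 to compound 4 (beyond the scatter), which is also the first such step at this position, though it remains modest and rests on a single pair of compounds. Nothing measured here bears on what lies behind these steps.

The compounds shown all carry an aromatic ring at this position, so it remains open how the read-out responds to a non-aromatic group there, such as a cyclohexyl ring or a longer alkyl chain. On these data alone, each compound also has just one reading at one concentration, so how the read-out changes with concentration remains open too.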